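The compounds below may be only part of what the source reports. "The series", "measured", "known", "first", "only" and "open" are said of these compounds alone.

Working notes on the series. In a functional assay on HeLa cells (Homo sapiens) for cytotoxicity (on this read-out higher numbers stand for weaker inhibition and lower numbers for stronger inhibition), compound 1 (`O=C(OC1=CC(=O)c2ccccc2C1=O)c1ccccc1`) gives 55000 nM, compound 2 (`COc1ccc2c(c1)C(=O)C=CC2=O`) gives 22700 nM and compound 3 (`CCCCOC1=CC(=O)c2ccccc2C1=O`) gives 35300 nM. Compound 2 and compound 3 lie within the scatter of each other, while compound 1 stands at a higher number than compound 2, beyond the scatter.

Compound 4 (`CS(=O)(=O)Oc1ccc2c(c1)C(=O)C=CC2=O`) departs from compound 2 by a single change: methylsulfonyl in place of methyl on an oxygen on an aromatic ring. In words, methylsulfonyl sits in place of methyl on an oxygen on an aromatic ring, which reads as methoxy to (methylsulfonyl)oxy.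

Going by the values given here, no measured pair differs in one place, and this change has no direct precedent here. Among the compounds with values here, the only guide is the narrow span of the measured compounds, from compound 2 at 22700 nM to compound 1 at 55000 nM. A small move toward a higher number, not beyond the scatter, is expected in this assay, and the estimated step is a 1.2-fold higher number from compound 2 to compound 4 (0.09 log units; within the scatter). Compound 4 is estimated at 28000 nM, with an expected range of 10000 nM to 70000 nM.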

Compound 4, half-maximal inhibitory concentration: 17700 nM
For compound 4 the middle estimate is 1.6-fold (0.20 log units) above the measured one, and the stated range covers the measured number.
By their numbers in this assay, from the lowest: compounds 4, 2, 3 and 1 (each within the scatter of the next, the first and the last beyond it).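

In this assay, going by these compounds alone, the step from methoxy to (methylsulfonyl)oxy gives the first one-place comparison: a 1.3-fold lower number from compound 2 to compound 4 (0.11 log units; within the scatter). On an oxygen on an aromatic ring, methylsulfonyl with 4 heavy atoms and 2 hydrogen-bond acceptors therefore replaces methyl with 1 heavy atom and none, without a separation beyond the scatter. No supporting data bear on why the read-out stays within the scatter across this change.

This single pair leaves open whether any group on this oxygen can move the read-out beyond the scatter, for example a carboxylic acid, an amine or a longer chain. It also cannot show whether the same exchange would give a similar step at another place on the shared core.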